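The source may report more compounds than this note shows. Statements on the series, on what has been measured and on what is new or still open speak of the compounds shown alone.

Working notes on the series. Three measured compounds share a sulfonyl-piperidine core carrying a methylpiperidine. Compound 1 `Cc1c(C)c(S(=O)(=O)N2CCC(N3CCC(C)CC3)CC2)c(C)c2c1OC(C)(C)C2` gives 1.12 h in an ADME assay on S9 fraction from liver (Mus musculus, strain ICR/CD-1) for metabolic stability, read by LC-MS, using NADPH, with a stated time of 5 min, tested at 2 uM; a higher number here means that the compound lasts longer, a lower number that the compound disappears faster. Compound 2 `COc1ccc(-c2cccc(S(=O)(=O)N3CCC(N4CCC(C)CC4)CC3)c2)cc1` gives 2.4 h in this assay, and compound 3 `CC1CCN(C2CCN(S(=O)(=O)c3ccc(Cl)c(C(F)(F)F)c3)CC2)CC1` gives 0.533 h in this assay. Compound 2 thus holds the longest half-life of the three; its gap to compound 1 and its wider gap to compound 3 both lie beyond the usual scatter of repeated measurements.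

Compound 4 `Cc1ccc(-c2cccc(S(=O)(=O)N3CCC(N4CCC(C)CC4)CC3)c2)cc1` has not yet been measured. It differs from compound 2 by methyl in place of methoxy on an aromatic carbon. Among the measured compounds shown here, no pair among the measured compounds shows this same change, so the size and direction of the step rest on nothing measured here. The expectation is a step of a 1.2-fold lower number from compound 2 to compound 4 (0.08 log units; within the scatter) in this assay that stays within the scatter, leaning if anything toward a somewhat shorter half-life. Compound 4 is therefore expected to give about 2 h in this assay, with a range from 0.9 h to 4.5 h.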

Compound 4, half-life: 1.92 h
Estimate against measurement, compound 4: 1.0-fold (0.02 log units) above; measured number inside the range.
By their numbers in this assay, from the lowest: compound 3; then compounds 1, 4 and 2 (each within the scatter of the next, the first and the last beyond it).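

Among the compounds shown here, the step from methoxy to methyl is the first comparison that isolates a single place, and in this assay it reads a 1.3-fold lower number from compound 2 to compound 4 (0.10 log units; within the scatter). At this place on the aromatic ring, para to a large group, the half-life therefore does not depend on methoxy specifically: methyl, with one heavy atom and no hydrogen-bond acceptor, serves within the scatter. The earlier compounds shown here differ in more than one place and could not show this.

Nothing available here explains the size of this step or identifies where the compounds are broken down. From the compounds shown here alone, whether a fluorine, a carboxylic acid or an amine at this place would give a similar half-life remains open.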